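Swapping isopropoxy for methoxy on a pyridine aryl nicotinic agonist

The source may hold more compounds than are shown below. What is called first, only, known or untested is meant among the compounds shown, and "the series" means these compounds.

Measured compounds:
compound 1, `COc1cncc(C2=CC3CC(C2)CN(C)C3)c1`: 5130 nM
compound 2, `CC(C)Oc1cncc(C2=CC3CNCC(C2)C3)c1`: 562 nM

In an in vitro functional assay on SH-EP1 cells for agonist activity at Neuronal acetylcholine receptor; alpha4/beta2 (Homo sapiens), read by FLIPR and calcium flux (on this read-out lower numbers stand for an effect already at smaller amounts and higher numbers for an effect only at larger amounts of compound), compound 2 gives 562 nM, the lower of the two numbers, and compound 1 gives 5130 nM, a gap that lies beyond the usual scatter. Compound 3, `COc1cncc(C2=CC3CNCC(C2)C3)c1`, has not yet been measured. It differs from compound 2 in one place: methyl in place of isopropyl on an oxygen on an aromatic ring. Compound 1 also carries a methoxy group, yet it differs from compound 3 elsewhere as well, so the two measured values give no clean reading of the isopropyl-to-methyl swap on its own. With no single-change comparison available, the expectation rests on the two measured values alone. Compound 3 is expected to land between them, closer to compound 2, with the step of a 2.7-fold higher number from compound 2 to compound 3 (0.43 log units; beyond the scatter) towards a higher number. The estimate for compound 3 is 1500 nM, within 500 nM to 5000 nM.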

Compound 3, half-maximal effective concentration: 53 nM
For compound 3 the middle estimate is 28-fold (1.45 log units) above the measured one; measured number outside the range, below it.
By their numbers in this assay, from the lowest: compound 3; then compound 2; then compound 1.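

In this assay, the change from isopropoxy to methoxy on the aromatic ring gives an 11-fold lower number from compound 2 to compound 3 (1.03 log units; beyond the scatter), so the size of the group on this oxygen matters, and the smaller group gives the lower number. The methoxy group is the same in the other pair, where hydrogen in place of methyl on the ring amine nitrogen gives a 97-fold lower number from compound 1 to compound 3 (1.99 log units; beyond the scatter), which shows that this second site also strongly affects the number. Nothing measured here explains why either change has this effect. On these data alone, whether an ethoxy group would land nearer methoxy or isopropoxy on this ring remains open, as does the outcome for a hydroxyl group. As far as these compounds go, it is also open whether the isopropoxy-to-methoxy step would be the same size with methyl on the amine nitrogen.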